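A few compounds are considered here, and "the series" means these few. Any claim that something is new, unique, unknown or untested is made for them only; others in the source may bear on it.

Measured so far in a functional assay on Shh Light II cells (Mus musculus) for inhibition, read by a luciferase reporter; on this read-out lower numbers stand for stronger inhibition and higher numbers for weaker inhibition:
- compound 1 `O=C(Nc1ccccc1Cl)N1CCC(c2nc(-c3ccc4ccccc4n3)no2)CC1`: 510 nM
- compound 2 `O=C(NC1CCC(O)CC1)N1CCC(c2nc(-c3ccc4ccccc4n3)no2)CC1`: 2700 nM
- compound 3 `O=C(Nc1ncccc1Cl)N1CCC(c2nc(-c3ccc4ccccc4n3)no2)CC1`: 2800 nM

The upper end of this small range is shared, with a 1.0-fold higher number from compound 2 to compound 3 (0.02 log units; within the scatter), against a 5.5-fold higher number from compound 1 to compound 3 (0.74 log units; beyond the scatter).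

Still open, on these data alone, is compound 4 `O=C(NC1CCOCC1)N1CCC(c2nc(-c3ccc4ccccc4n3)no2)CC1`. The change is oxan-4-yl in place of 3-chloropyridin-2-yl on an amide-type nitrogen.

Going by the values given here, the closest precedent is a 1.0-fold higher number from compound 2 to compound 3 (0.02 log units; within the scatter), which also pairs 3-chloropyridin-2-yl with a non-aromatic ring at that place. The other non-aromatic case, a 5.3-fold higher number from compound 1 to compound 2 (0.72 log units; beyond the scatter), lands at the same level. No step beyond the scatter is therefore expected in this assay.

The expected step is a 1.1-fold higher number from compound 3 to compound 4 (0.03 log units; within the scatter).

Compound 4 is estimated at 3000 nM, with an expected range of 1200 nM to 7500 nM.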

Compound 4, half-maximal inhibitory concentration: 480 nM
Estimate against measurement, compound 4: 6.3-fold (0.80 log units) above, and the stated range ends above it.
By their numbers in this assay, from the lowest: compounds 4 and 1 (each within the scatter of the next); then compounds 2 and 3 (each within the scatter of the next).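

In this assay, a non-aromatic ring on the amide-type nitrogen does not by itself set the level: oxan-4-yl separates from 3-chloropyridin-2-yl (a 5.8-fold lower number from compound 3 to compound 4 (0.77 log units; beyond the scatter)) and also from the non-aromatic 4-hydroxycyclohexyl (a 5.6-fold lower number from compound 2 to compound 4 (0.75 log units; beyond the scatter)). Oxan-4-yl and the aromatic 2-chlorophenyl stand level (a 1.1-fold lower number from compound 1 to compound 4 (0.03 log units; within the scatter)), so aromatic and non-aromatic rings both occur at the lower level. No supporting data bear on the reason for these steps.

Open, on these data alone, is how cyclohexyl, without a ring hetero atom, would compare with oxan-4-yl. Piperidin-4-yl, which carries an amine in the ring, and an open-chain 2-methoxyethyl also remain untested in this series.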